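Replacing 3,4-dichlorophenyl with ethyl on the shared core

The source may report more compounds than this note shows. Statements on the series, on what has been measured and on what is new or still open speak of the compounds shown alone.

Of the compounds shown here, two sharing one core have been measured in a functional assay on MCF7 cells (Homo sapiens) for antiproliferative activity, read by MTT assay, with a stated time of 48 h; on this read-out higher numbers stand for weaker inhibition and lower numbers for stronger inhibition. Compound 1 `O=C(/C=C/c1ccc(O)c(O)c1)N1CCN(c2ccccc2Cl)CC1` gives 1.36 ug/mL, and compound 2 `O=C(/C=C/c1ccc(O)c(O)c1)N1CCN(c2ccc(Cl)c(Cl)c2)CC1` gives 1.28 ug/mL. Compound 2 therefore stands level with compound 1 within the usual scatter. For the measured compounds named here, the only measured step is a 1.1-fold lower number from compound 1 to compound 2 (0.03 log units; within the scatter), which exchanges 2-chlorophenyl for 3,4-dichlorophenyl on an amine nitrogen in a ring.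

Compound 3 `CCN1CCN(C(=O)/C=C/c2ccc(O)c(O)c2)CC1` has not yet been measured in this assay. Its difference from compound 2 is ethyl in place of 3,4-dichlorophenyl on an amine nitrogen in a ring, with ethyl in place of 3,4-dichlorophenyl on the same nitrogen. The measured step swaps one chlorinated phenyl for another, so it offers only limited guidance here, where the aromatic ring leaves and no ring enters. Going by the values given here, no measured compound lacks a ring at this place, and the direction of the change remains uncertain. A moderate move towards weaker inhibition is tentatively expected, given as a 2.0-fold higher number from compound 2 to compound 3 (0.29 log units; within the scatter). Compound 3 is estimated at 2.5 ug/mL, with an expected range of 0.9 ug/mL to 10 ug/mL.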

Compound 3, half-maximal inhibitory concentration: 2.06 ug/mL
Beside the measured number, compound 3's estimate is 1.2-fold (0.08 log units) above it, within the range that was stated.
By their numbers in this assay, from the lowest: compounds 2, 1 and 3 (each within the scatter of the next).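

In this assay the earlier pair only exchanged one chlorinated phenyl for another, whereas here the aromatic ring leaves the amine nitrogen in a ring altogether and ethyl takes its place, with no ring entering. That exchange, from 8 heavy atoms to 2, still stays inside the usual scatter, both for the step from the dichlorinated compound (a 1.6-fold higher number from compound 2 to compound 3 (0.21 log units; within the scatter)) and for the step from the monochlorinated one (a 1.5-fold higher number from compound 1 to compound 3 (0.18 log units; within the scatter)). This position therefore accepts a small open-chain group as well as a chlorinated phenyl on the shared core in this assay, and nothing available bears on the reason for this.

The compounds shown leave open how far this tolerance extends, for example whether a plain unsubstituted phenyl, a benzyl group, a longer chain such as butyl, or a chain ending in a carboxylic acid would also stay level with these three. They also leave open whether the same holds once the rest of the core changes, since all three carry the same remainder and differ only on this nitrogen.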